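The source may hold more compounds than are shown below. What is called first, only, known or untested is meant among the compounds shown, and "the series" means these compounds.

Compound 1 `CS(=O)(=O)Nc1ccc(-c2nc3ccccc3o2)cc1` — > 100000 nM
Compound 2 `C=Cc1ccc(S(=O)(=O)Nc2ccc(-c3nc4ccccc4o3)cc2)cc1` — > 100000 nM
Compound 3 `O=S(=O)(Nc1ccc(-c2nc3ccccc3o2)cc1)c1ccc(F)cc1` — 73000 nM

In an assay on cells for inhibition of HSP60/HSP10 (Homo sapiens), with a stated time of 60 min (a lower number here means a stronger inhibitor, a higher number a weaker inhibitor), compound 1 reaches only a limit, > 100000 nM. Compound 2 likewise gives only a limit, > 100000 nM. For the measured compounds named here, compound 3 gives the sole number in this assay, 73000 nM, which places it on the limit of > 100000 nM in this assay, at which 2 of the 3 values shown sit, side of nothing: it is the one compound with a readable value. The measured steps of an at least 1.3-fold lower number from compound 1 to compound 3 (0.13 log units; that floor lies within the scatter) and an at least 1.3-fold lower number from compound 2 to compound 3 (0.13 log units; that floor lies within the scatter) are both floors set by that limit. Compound 4 `COc1ccc(S(=O)(=O)Nc2ccc(-c3nc4ccccc4o3)cc2)cc1` carries the change (methoxy in place of fluoro on an aromatic carbon). Going by the values given here, no measured step covers a methoxy group here; the nearest, a fluoro replacing a vinyl, gave no readable size. Compound 4 is therefore expected to stay within the scatter of compound 3, estimated at 60000 nM between 20000 nM and 200000 nM, an expected step of a 1.2-fold lower number from compound 3 to compound 4 (0.09 log units; within the scatter).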

Compound 4, half-maximal inhibitory concentration: > 100000 nM
Compound 4: a limit, no number (the forecaster's own chance of this, stated with the estimate: 35%); middle value at least 1.6-fold (0.22 log units) from the limit.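

In this assay, the change from 4-fluorophenyl to 4-methoxyphenyl gives an at least 1.3-fold higher number from compound 3 to compound 4 (0.13 log units; that floor lies within the scatter). Among the groups shown on this aromatic carbon, fluoro therefore remains the only one with a readable value, since methoxy, like vinyl, ends at a limit. The steps to compound 4 from compound 1 and from compound 2 cannot be read, and most of the set now rests at one limit: the limit of > 100000 nM in this assay, at which 3 of the 4 values shown sit.

On these data alone, whether a chloro group, an amine or a carboxylic acid on this carbon would give a readable value stays open.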